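Urea series: 2-methylphenyl in place of 4-methoxyphenyl

The source may hold more compounds than are shown below. What is called first, only, known or untested is meant among the compounds shown, and "the series" means these compounds.

Measured so far:
compound 1 `COc1ccc(NC(=O)Nn2c(-c3ccccc3)nc3ccccc3c2=O)cc1`, 52%
compound 2 `Cc1ccc(NC(=O)Nn2c(-c3ccccc3)nc3ccccc3c2=O)cc1`, 54%
compound 3 `O=C(Nc1ccc([N+](=O)[O-])cc1)Nn1c(-c2ccccc2)nc2ccccc2c1=O`, 42%

In a functional assay on the whole organism (strain albino) with Mus musculus as the target, at a dose of 100 mg/kg by the intraperitoneal route (on this read-out lower numbers stand for less inhibition and higher numbers for more inhibition at the one dose given (going by the name of the read-out)), compound 1 gives 52%, the second highest of the three numbers. Compound 2 lies nearest, a number 2 percentage points higher from compound 1 to compound 2 (within the scatter); compound 3 lies furthest, a number 10 percentage points lower from compound 1 to compound 3 (within the scatter). Between the other two the difference is a number 12 percentage points lower from compound 2 to compound 3 (beyond the scatter). Compound 4 `Cc1ccccc1NC(=O)Nn1c(-c2ccccc2)nc2ccccc2c1=O` differs from compound 1 as follows: 2-methylphenyl in place of 4-methoxyphenyl on an amide-type nitrogen. Among the compounds with values here, the only measured step on the same amine side that swaps methoxy for methyl, a number 2 percentage points higher from compound 1 to compound 2 (within the scatter), stays within the scatter, and no measured compound carries the 2-methylphenyl group, so nothing speaks for a move beyond the scatter. The expected step is no change at the digits printed from compound 1 to compound 4 (within the scatter). Compound 4 is therefore estimated at 52% in this assay, with a range from 42% to 62%.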

Compound 4, a percentage reported as inhibition, in the whole organism at one dose (the size of the read-out at that dose, not a potency): 59%
The estimate for compound 4 lay 7 percentage points below the measured number, and the stated range covers the measured number.
By their numbers in this assay, from the lowest: compounds 3, 1, 2 and 4 (each within the scatter of the next, the first and the last beyond it).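

In this assay, 2-methylphenyl on the amide-type nitrogen reads the same as 4-methoxyphenyl and 4-methylphenyl, with a number 7 percentage points higher from compound 1 to compound 4 (within the scatter) and a number 5 percentage points higher from compound 2 to compound 4 (within the scatter) both staying inside the scatter. Only against 4-nitrophenyl does the new group separate, and a number 17 percentage points higher from compound 3 to compound 4 (beyond the scatter) is a modest step. No measurement bears on the reason for this.

As far as these compounds go, whether an amine or a carboxylic acid on this phenyl ring, or a longer chain in place of the methyl, would keep the number at this level stays open. Changes elsewhere on the shared core also remain untested here.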